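One Change on Two Cores: Expecting Compound 4

The source may hold more compounds than are shown below. What is called first, only, known or untested is meant among the compounds shown, and "the series" means these compounds.

Of the compounds shown here, three have so far been measured in an assay on Sf21 cells for inhibition of mitogen-activated protein kinase kinase kinase 13 (Homo sapiens), read by HTRF, with a stated time of 1.5 h; on this read-out lower numbers stand for stronger inhibition and higher numbers for weaker inhibition. Compound 1 `CCOC(=O)N1C[C@@H]2C[C@H]1CN2c1nc(-c2cnc(N)c(OC(F)F)n2)cc(N2CC3CC2C3)n1` gives 13 nM. Compound 3 `CCOC(=O)N1C[C@@H]2C[C@H]1CN2c1nc(-c2cnc(N)c(OC(F)F)n2)cc(C2CC2)n1` gives 45 nM. Compound 2 `Nc1ncc(-c2cc(C3CC3)nc(N3C[C@@H]4C[C@H]3CO4)n2)nc1OC(F)F` gives 61 nM; the gap between compound 2 and compound 3 lies within the scatter, so nothing can be said about which of those two is the stronger. The difference between the core of compound 2 and the core of compound 3 is not broken down here.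

From compound 3 to compound 1 a single change is made: a group of 6 heavy atoms (5 carbon, 1 nitrogen; one four-membered non-aromatic ring of carbon only, one five-membered non-aromatic ring with 1 hetero atom) in place of a group of 3 heavy atoms (3 carbon; one three-membered non-aromatic ring of carbon only), on an aromatic carbon. This change produced a 3.5-fold lower number from compound 3 to compound 1 (0.54 log units; beyond the scatter).

Compound 4 `Nc1ncc(-c2cc(N3CC4CC3C4)nc(N3C[C@@H]4C[C@H]3CO4)n2)nc1OC(F)F` has not yet been measured in this assay. It arises from compound 2 by the same kind of change: a group of 6 heavy atoms (5 carbon, 1 nitrogen; one four-membered non-aromatic ring of carbon only, one five-membered non-aromatic ring with 1 hetero atom) in place of a group of 3 heavy atoms (3 carbon; one three-membered non-aromatic ring of carbon only), on an aromatic carbon. The surroundings of the change are not identical, though: the place of the entering group, as given with each of the two differences above, is not described in the same way for compound 1 and for compound 4. Within the data shown here, because the one earlier example gave a 3.5-fold lower number from compound 3 to compound 1 (0.54 log units; beyond the scatter), a step of similar size is expected here, namely a 3.6-fold lower number from compound 2 to compound 4 (0.55 log units; beyond the scatter). For compound 4 the expected value in this assay is therefore 17 nM. Among the measured compounds shown here, the expected range for compound 4 runs from 7 nM to 45 nM, wide enough to allow for the single precedent and the altered surroundings.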

Compound 4, half-maximal inhibitory concentration: 35 nM
Compound 4: middle estimate off by 2.1-fold (0.31 log units), on the low side; measured number inside the range.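

In this assay, putting the six-heavy-atom group in place of cyclopropyl gives a 1.7-fold lower number from compound 2 to compound 4 (0.24 log units; within the scatter), so on the core of compound 2 this step alone cannot be told apart from the ordinary variation between repeated measurements. Set beside the earlier example, the step does not differ measurably between the two cores: the same change on two cores in this assay, a 3.5-fold lower number (0.54 log units; beyond the scatter) from compound 3 to compound 1 and a 1.7-fold lower number (0.24 log units; within the scatter) from compound 2 to compound 4, 2.0-fold (0.30 log units) apart, within the scatter of two such steps This shows that the results fit with the change carrying over from one core to the other, but it does not prove that it does, since only one of the two steps stands clear of the scatter, so neither a real gain on the core of compound 2 nor a smaller gain there than on the core of compound 3 is established.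

The compounds shown leave open which feature of the entering group matters, since the ring nitrogen and the four-membered ring arrive together and no compound here carries one without the other. They also leave open whether a simple open-chain amine such as dimethylamino, put in the place of cyclopropyl, would give a step of similar size, and whether any such step would hold on a third core.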